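Sulfamoyl in place of methylsulfonyl: compound 4

A few compounds are considered here, and "the series" means these few. Any claim that something is new, unique, unknown or untested is made for them only; others in the source may bear on it.

The measured set comprises compound 1 `CS(=O)(=O)c1ccc(-c2nc(SCCOC(=O)/C=C/c3ccc(O)c(O)c3)nn2-c2ccccc2)cc1`, compound 2 `CS(=O)(=O)c1ccc(-c2nc(SCCCOC(=O)/C=C/c3ccc(O)c(O)c3)nn2-c2ccc(Br)cc2)cc1` and compound 3 `CS(=O)(=O)c1ccc(-c2nc(SCCCOC(=O)/C=C/c3ccc(O)c(O)c3)nn2-c2ccc(F)cc2)cc1`. In a functional assay on Caco-2 cells (Homo sapiens) for antiproliferative activity, read by MTT assay, with a stated time of 72 h (a higher number here means a weaker inhibitor, a lower number a stronger inhibitor), compound 1 gives 14800 nM, compound 2 gives 12400 nM and compound 3 gives 11200 nM. Compound 1 holds the highest of the three numbers, yet its gaps to compound 2 and to compound 3 both lie within the scatter. Among the measured compounds shown here, the single step between measured neighbours, a 1.1-fold lower number from compound 2 to compound 3 (0.04 log units; within the scatter), is likewise within the scatter. Compound 4 `NS(=O)(=O)c1ccc(-c2nc(SCCOC(=O)/C=C/c3ccc(O)c(O)c3)nn2-c2ccccc2)cc1` differs from compound 1 by amino in place of methyl on a sulfonyl sulfur. For the measured compounds named here, no measured step touches the sulfonyl sulfur, so nothing in the set argues for a step in this assay beyond the scatter in either direction. Compound 4 is therefore expected at 14800 nM, between 6000 nM and 36000 nM, a step of no change at the digits printed from compound 1 to compound 4 (within the scatter).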

Compound 4, half-maximal inhibitory concentration: 15000 nM
For compound 4 the middle estimate is 1.0-fold (0.01 log units) below the measured one; the measured number falls inside the stated range.
By their numbers in this assay, from the lowest: compounds 3, 2, 1 and 4 (each within the scatter of the next).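

At the sulfonyl sulfur, amino in place of methyl gives in this assay a 1.0-fold higher number from compound 1 to compound 4 (0.01 log units; within the scatter), so on the core of compound 1 this one change, which adds a hydrogen-bond donor, leaves the read-out within the scatter. The earlier compounds shown here held no step at this position. No available evidence speaks to why methylsulfonyl and sulfamoyl read alike here. Open, on these data alone, is whether a larger group on the sulfonyl sulfur, such as dimethylamino, or a carboxylic acid in place of the sulfonyl group, would shift the number. Also open, as far as these compounds go, is whether the same change reads alike on compound 2 or compound 3.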